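The compounds below may be only part of what the source reports. "The series", "measured", "known", "first", "only" and "open" are said of these compounds alone.

Of the compounds shown here, three built on one shared core have been tested in an assay on isolated protein for binding affinity to melanin-concentrating hormone receptor 1 (Homo sapiens); on this read-out higher numbers stand for weaker inhibition and lower numbers for stronger inhibition. Compound 1 `O=C(NC1CCN(Cc2ccc3ccccc3c2)CC1)c1ccccc1` gives 347 nM. Compound 2 `COc1cccc(C(=O)NC2CCN(Cc3ccc4ccccc4c3)CC2)c1` gives 29 nM, and compound 3 `COc1cc(OC)cc(C(=O)NC2CCN(Cc3ccc4ccccc4c3)CC2)c1` gives 27 nM. Compound 3 has the lowest number of the three, yet its gap to compound 2 lies within the scatter, so the two cannot be told apart; only compound 1 stands clearly apart as the weaker binder. Compound 4 `COc1ccc(C(=O)NC2CCN(Cc3ccc4ccccc4c3)CC2)cc1OC` differs from compound 3 in one place: 3,4-dimethoxyphenyl in place of 3,5-dimethoxyphenyl on a carbonyl carbon. Among the compounds with values here, the steps that bear on this are a 12-fold lower number from compound 1 to compound 2 (1.08 log units; beyond the scatter) and a 13-fold lower number from compound 1 to compound 3 (1.11 log units; beyond the scatter), both large, and a 1.1-fold lower number from compound 2 to compound 3 (0.03 log units; within the scatter), which shows that a second methoxy on the phenyl added little. Since compound 2 and compound 3 both carry methoxy on the phenyl and sit close together, and compound 4 keeps two methoxy groups on that ring, the change is expected to stay near the scatter, a 1.5-fold higher number from compound 3 to compound 4 (0.17 log units; within the scatter). Compound 4 is therefore estimated at 40 nM in this assay, with a range from 15 nM to 120 nM.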

Compound 4, inhibition constant: 1000 nM
For compound 4 the middle estimate is 25-fold (1.40 log units) below the measured one; the measured number lies above the stated range.
By their numbers in this assay, from the lowest: compounds 3 and 2 (each within the scatter of the next); then compound 1; then compound 4.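

In this assay, the placing of the two methoxy groups on the phenyl ring turns out to matter, not just their presence: the same atoms joined differently, as 3,4-dimethoxyphenyl in place of 3,5-dimethoxyphenyl, give a large change (a 37-fold higher number from compound 3 to compound 4 (1.57 log units; beyond the scatter)). Compound 4 also binds more weakly than the compound with one methoxy group (a 34-fold higher number from compound 2 to compound 4 (1.54 log units; beyond the scatter)) and even than the compound with a plain phenyl (a 2.9-fold higher number from compound 1 to compound 4 (0.46 log units; beyond the scatter)), so it goes against the earlier pattern in which methoxy groups lowered the number. No available evidence accounts for this reversal.

From the compounds shown here alone, it remains open which of the two methoxy groups in 3,4-dimethoxyphenyl goes with the higher number. Also open, going by these compounds, is how other groups on this ring, such as a hydroxyl, a fluorine or an amine, would behave.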